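Methoxy-bearing amide variants on a shared sulfonylpiperidine core

A few compounds are considered here, and "the series" means these few. Any claim that something is new, unique, unknown or untested is made for them only; others in the source may bear on it.

Measured compounds in a functional assay on MIA PaCa-2 cells (Homo sapiens) for inhibition, read by MTT assay, with a stated time of 7 days; a higher number here means a weaker inhibitor, a lower number a stronger inhibitor:
compound 1 `CCN(CC)S(=O)(=O)c1ccc(S(=O)(=O)N2CCC[C@@H](C(=O)N[C@H]3CC[C@H](OC)CC3)C2)cc1` gives 1350 nM
compound 2 `CCN(CC)S(=O)(=O)c1ccc(S(=O)(=O)N2CCC[C@@H](C(=O)N3CCC(COC)CC3)C2)cc1` gives 250 nM
compound 3 `CCN(CC)S(=O)(=O)c1ccc(S(=O)(=O)N2CCC[C@@H](C(=O)N3CC[C@@H](OC)C3)C2)cc1` gives 3910 nM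

Compound 1 stands second highest of the three numbers. Compound 2 sits well under it, and the step of a 5.4-fold lower number from compound 1 to compound 2 (0.73 log units; beyond the scatter) is beyond the scatter. Compound 3 sits above it, and the step of a 2.9-fold higher number from compound 1 to compound 3 (0.46 log units; beyond the scatter) is also beyond the scatter. Between the two extremes the step of a 16-fold higher number from compound 2 to compound 3 (1.19 log units; beyond the scatter) is the largest of the set.

Compound 4 `CCN(CC)S(=O)(=O)c1ccc(S(=O)(=O)N2CCC[C@@H](C(=O)N3CC[C@H](OC)C3)C2)cc1` is not yet measured. Against compound 1 the change is 3-methoxypyrrolidin-1-yl in place of (4-methoxycyclohexyl)amino on a carbonyl carbon. Within the data shown here, compound 3 carries the same entering group, with its one defined stereocentre in the other configuration, so the step from compound 1 to compound 3 is the only direct guide. That step was modest and upward in number. As far as these compounds go, whether the opposite configuration reproduces it is unknown from these data, so the expectation is wide.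

Among the measured compounds shown here, compound 4 is therefore expected to give a higher number than compound 1, with the step of a 2.2-fold higher number from compound 1 to compound 4 (0.35 log units; beyond the scatter) estimated close to the one seen for compound 3. The estimate for compound 4 in this assay is 3000 nM, with a range from 1100 nM to 8500 nM.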

Compound 4, half-maximal inhibitory concentration: 2460 nM
The estimate for compound 4 lay 1.2-fold (0.09 log units) above the measured number; measured number inside the range.
By their numbers in this assay, from the lowest: compound 2; then compounds 1, 4 and 3 (each within the scatter of the next, the first and the last beyond it).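

Configuration at the saturated ring carbon can now be read in this assay, and the step of a 1.6-fold lower number from compound 3 to compound 4 (0.20 log units; within the scatter) gives no separation between the two forms of the 3-methoxypyrrolidin-1-yl amide, a comparison that isolates this one feature: the fact that compounds 3 and 4 differ only in the configuration as drawn.
The step of a 1.8-fold higher number from compound 1 to compound 4 (0.26 log units; within the scatter) also means that the change from (4-methoxycyclohexyl)amino to 3-methoxypyrrolidin-1-yl does not give a step beyond the scatter in both configurations, so the earlier reading from compound 3 alone does not hold for this change as a whole.
The gap to 4-(methoxymethyl)piperidin-1-yl is beyond the scatter in both configurations, with the step of a 9.8-fold higher number from compound 2 to compound 4 (0.99 log units; beyond the scatter) standing alongside the step of a 16-fold higher number from compound 2 to compound 3 (1.19 log units; beyond the scatter), so compound 2 remains apart from both pyrrolidine amides.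

As far as these compounds go, whether the methoxy oxygen contributes to the low number of compound 2 stays open, and a 4-(hydroxymethyl)piperidin-1-yl or an unsubstituted piperidin-1-yl amide would address that question.
The carbon of the shared core bearing the carbonyl keeps one configuration as drawn in all four compounds, so any role for its configuration cannot be read here.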